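A few compounds are considered here, and "the series" means these few. Any claim that something is new, unique, unknown or untested is made for them only; others in the source may bear on it.

- Compound 1 `CCCCCCCOc1ccc(CCC(CO)(CO)NC(C)=O)c2ccccc12`: 17600 nM
- Compound 2 `CCCCCCCOc1ccc(CCC(CO)(CO)NC(=O)CCCCC)c2ccccc12`: 21900 nM

Both values come from a functional assay on HT-29 cells (Homo sapiens) for antiproliferative activity, read by sulforhodamine B assay, with a stated time of 72 h; on this read-out higher numbers stand for weaker inhibition and lower numbers for stronger inhibition. Going by the values given here, only two numbers are available so far, and they lie within the scatter of each other, so compound 2 stands level with compound 1, its nearest neighbour. Among the compounds with values here, the one measured step is a 1.2-fold higher number from compound 1 to compound 2 (0.09 log units; within the scatter). It places butyl in place of hydrogen on a saturated chain carbon bound to a carbonyl carbon, and it does not rise above the scatter.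

Compound 3 `CCCCCCCOc1ccc(CCC(CO)(CO)NC(=O)CCCCCCC)c2ccccc12` extends the acyl chain of compound 2 further, and the change is this: ethyl in place of hydrogen on a saturated chain carbon, five bonds along the chain from a carbonyl carbon. Within the data shown here, no measured compound carries a chain this long, so the evidence is a single step. That step, a 1.2-fold higher number from compound 1 to compound 2 (0.09 log units; within the scatter), added butyl, a larger addition than the ethyl added here, and it left the number within the scatter. No shift beyond the scatter is therefore expected in this assay, and no direction can be favoured. The expected step is a 1.0-fold higher number from compound 2 to compound 3 (0.00 log units; within the scatter). For compound 3 the estimated value is 22000 nM, with an expected range from 11000 nM to 45000 nM.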

Compound 3, half-maximal inhibitory concentration: 18800 nM
For compound 3 the middle estimate is 1.2-fold (0.07 log units) above the measured one; the measured number falls inside the stated range.
By their numbers in this assay, from the lowest: compounds 1, 3 and 2 (each within the scatter of the next).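

In this assay, ethyl in place of hydrogen on a saturated chain carbon, five bonds along the chain from a carbonyl carbon, gives a 1.2-fold lower number from compound 2 to compound 3 (0.07 log units; within the scatter), so a second addition to the acyl chain leaves the number as level as the butyl addition did. The full length can also be read in one step: the whole extension of the acyl chain gives a 1.1-fold higher number from compound 1 to compound 3 (0.03 log units; within the scatter), which shows that even this largest addition among the three compounds does not rise above the scatter, and compound 1, compound 2 and compound 3 stand level at this position. No measurement of any other kind is available that bears on this flat result.

The compounds shown leave open whether a still longer chain on the carbonyl carbon, or an amine or a carboxylic acid at the end of that chain, would move the number beyond the scatter. They also leave open whether a change in the shared core, such as a carboxylic acid in place of a hydroxyl, would move it when the acyl chain does not.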